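Chloro on the anilide ring of a cyanoacetamide thiazolidinone

This account rests on a few compounds, and the source may have more. Where it says the series, first, only, none or still open, it means among the compounds named here.

Measured compounds:
compound 1 `N#C/C(C(=O)Nc1ccccc1)=c1/s/c(=C\c2ccccc2)c(=O)n1-c1ccccc1` — 33300 nM
compound 2 `N#C/C(C(=O)Nc1ccccc1)=c1/s/c(=C\c2ccccc2O)c(=O)n1-c1ccccc1` — 7800 nM

In a functional assay on HCT-116 cells (Homo sapiens) for cytotoxicity, read by sulforhodamine B assay, with a stated time of 48 h (a higher number here means a weaker inhibitor, a lower number a stronger inhibitor), compound 1 gives 33300 nM, the highest of the two numbers in hand. Its nearest neighbour is compound 2, which in this assay gives 7800 nM; the step of a 4.3-fold lower number from compound 1 to compound 2 (0.63 log units; beyond the scatter) is modest but beyond the scatter. That step concerns a hydroxy group on the benzylidene ring.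

Compound 3 `N#C/C(C(=O)Nc1ccc(Cl)cc1)=c1/s/c(=C\c2ccccc2)c(=O)n1-c1ccccc1` differs from compound 1 in one place: chloro in place of hydrogen on an aromatic carbon, phenylcarbamoyl to (4-chlorophenyl)carbamoyl. Within the data shown here, no measured pair shows a change on that anilide ring; the only step in hand, from compound 1 to compound 2, sits on another ring and so does not bear directly on this change. With nothing to point in either direction, the expected step of a 1.3-fold lower number from compound 1 to compound 3 (0.12 log units; within the scatter) is small, and a number close to that of compound 1 is the most reasonable guess. Compound 3 is therefore estimated at 25000 nM in this assay, with a range from 8000 nM to 80000 nM.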

Compound 3, half-maximal inhibitory concentration: 38900 nM
For compound 3 the middle estimate is 1.6-fold (0.19 log units) below the measured one, within the range that was stated.
By their numbers in this assay, from the lowest: compound 2; then compounds 1 and 3 (each within the scatter of the next).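

In this assay, putting chloro on this six-membered aromatic ring, para to a large group, gives (a 1.2-fold higher number from compound 1 to compound 3 (0.07 log units; within the scatter)), so compound 1 and compound 3 cannot be told apart. Among these compounds, this is the first reading at this ring, and it shows that phenylcarbamoyl and (4-chlorophenyl)carbamoyl are interchangeable here, at least for this one substituent on the core of compound 1, whereas the hydroxy step elsewhere in the molecule (a 4.3-fold lower number from compound 1 to compound 2 (0.63 log units; beyond the scatter)) lies beyond the scatter. Nothing in hand explains the flat result.

What the compounds shown leave open is whether this position tolerates anything else, since a single chloro cannot speak for a methoxy group, an amine or a carboxylic acid at the same place, nor for chloro elsewhere on the ring. From the compounds shown here alone, it is also open whether the flat chloro step holds on the background of compound 2, where the hydroxy group is already present, as a step read on compound 1 need not carry over to another member of the series.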